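This account rests on a few compounds, and the source may have more. Where it says the series, first, only, none or still open, it means among the compounds named here.

Measured so far in a functional assay on WI-38 cells (Homo sapiens) for inhibition; a lower number here means a stronger inhibitor, a higher number a weaker inhibitor:
compound 1, `CC(O)n1cnc2c(Cl)nc(I)nc21`: > 500000 nM
compound 2, `CC(O)n1cnc2c(N)nc(I)nc21`: > 500000 nM

Both values are limits of the assay rather than numbers. In this assay compound 1 gives only a limit, > 500000 nM. In this assay compound 2 likewise gives only a limit, > 500000 nM. Going by the values given here, the single measured step, a step that the two limits leave unreadable from compound 1 to compound 2, is therefore of unreadable size; all that the two values show is the limit of > 500000 nM in this assay, at which 2 of the 2 values shown sit. Compound 2 thus stands at the limit, with no number to place it against any other compound.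

Compound 3, `Nc1nc(I)nc2c1ncn2OCCO`, differs from compound 2 by 2-hydroxyethoxy in place of 1-hydroxyethyl on an aromatic nitrogen. Among the compounds with values here, no measured step bears on a change of this kind on the ring nitrogen, and the only step gives no size at all. The step expected in this assay is a step that the limit leaves unreadable from compound 2 to compound 3, nothing readable beyond the scatter. The estimate for compound 3 in this assay is 1000000 nM, in the range 300000 nM to 5000000 nM, most likely reported again only as a limit.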

Compound 3, half-maximal inhibitory concentration: > 500000 nM
Compound 3: a limit, no number; the forecaster's own chance of this, stated with the estimate: 85%; the middle value is on the limit's open side.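

In this assay, going by these compounds alone, compound 3 gives only a limit, > 500000 nM, so no step from compound 2 to compound 3 can be read. The compounds shown leave open what change on the shared core, if any, would give a readable number, since all rest at one value: the limit of > 500000 nM in this assay, at which 3 of the 3 values shown sit.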